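Trifluoromethyl on the Benzyl Group: Expected Cytotoxicity

A few compounds are considered here, and "the series" means these few. Any claim that something is new, unique, unknown or untested is made for them only; others in the source may bear on it.

Measured so far in an ADME assay on RAW264.7 cells (Mus musculus) for cytotoxicity, read by MTT assay, with a stated time of 72 h, tested at 50 uM; a higher number here means more inhibition at the concentration tested (going by the name of the read-out), a lower number less inhibition:
Compound 1, `CCOC(=O)c1sc(-c2ccccc2)nc1N1CCC(NCc2ccccc2)CC1`, gives 11.7%.
Compound 2, `CCOC(=O)c1sc(-c2ccccn2)nc1N1CCC(NCc2ccccc2)CC1`, gives 14.6%.

Compound 2 stands highest of the two numbers, though its step of a number 2.9 percentage points higher from compound 1 to compound 2 (within the scatter) lies within the scatter, so no order between the two can be claimed. Compound 3, `CCOC(=O)c1sc(-c2ccccn2)nc1N1CCC(NCc2ccc(C(F)(F)F)cc2)CC1`, differs from compound 2 by trifluoromethyl in place of hydrogen on an aromatic carbon. No measured step touches the benzyl group, so nothing shown bears directly on this change. For the measured compounds named here, the only known step is small and within the scatter, and a comparably small step is expected here, with an estimated step of a number 4.4 percentage points higher from compound 2 to compound 3 (within the scatter). Compound 3 is therefore expected to give about 19%, in the range 5% to 38%.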

Compound 3, a percentage reported as inhibition, at one concentration (the size of the read-out at that concentration, not a potency): 14.6%
Compound 3: middle estimate off by 4.4 percentage points, on the high side; measured number inside the range.
By their numbers in this assay, from the lowest: compounds 1, 2 and 3 (each within the scatter of the next).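

This is the first step shown on the benzyl group, where the earlier compounds changed only the other aromatic ring. In this assay, trifluoromethyl in place of hydrogen gives no change at the digits printed from compound 2 to compound 3 (within the scatter), so this larger group at this place of the ring leaves the read-out indistinguishable from that of hydrogen. Nothing shown explains this result. Going by these compounds, whether an amine or a carboxylic acid at the same place would also match hydrogen remains open. So does the effect of a methoxy group or a chlorine atom there.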